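The compounds below may be only part of what the source reports. "The series", "measured", "known", "first", "only" and "open" are said of these compounds alone.

Compound 1 `O=Cc1ccccc1OCc1cn(CCCOc2ccc3ccc(=O)oc3c2)nn1` and compound 2 `O=Cc1cc(Br)ccc1OCc1cn(CCCOc2ccc3ccc(=O)oc3c2)nn1` share a core; how that core differs from the core of compound 3 `NS(=O)(=O)c1ccc(C/N=C/c2ccccc2OCc2cn(CCCOc3ccc4ccc(=O)oc4c3)nn2)cc1` is not broken down here. In a functional assay on HT-29 cells (Homo sapiens) for cytotoxicity, read by MTT assay, with a stated time of 24 h (on this read-out higher numbers stand for weaker inhibition and lower numbers for stronger inhibition), compound 1 gives 18900 nM, compound 2 gives 7470 nM and compound 3 gives 14300 nM. The change from compound 1 to compound 2 is bromo in place of hydrogen on an aromatic carbon, and it made a 2.5-fold lower number from compound 1 to compound 2 (0.40 log units; beyond the scatter). Compound 4 `NS(=O)(=O)c1ccc(C/N=C/c2cc(Br)ccc2OCc2cn(CCCOc3ccc4ccc(=O)oc4c3)nn2)cc1` carries the same kind of change from compound 3, (bromo in place of hydrogen on an aromatic carbon); here the place is meta to a large group rather than meta to a formyl group (2 heavy atoms), while it remains para to a large group in both. Because the earlier step was a 2.5-fold lower number from compound 1 to compound 2 (0.40 log units; beyond the scatter), a step of about a 2.2-fold lower number from compound 3 to compound 4 (0.34 log units; beyond the scatter) is expected from compound 3 to compound 4. Compound 4 is therefore estimated at 6500 nM, with a likely range from 2500 nM to 15000 nM.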

Compound 4, half-maximal inhibitory concentration: 17700 nM
The estimate for compound 4 lay 2.7-fold (0.44 log units) below the measured number; the measured number lies above the stated range.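

In this assay, bromo in place of hydrogen on an aromatic carbon gives a 1.2-fold higher number from compound 3 to compound 4 (0.09 log units; within the scatter), so this change has no clear effect on the core of compound 3. The change therefore does not carry over unaltered from the core of compound 1 to the core of compound 3: the same change on two cores in this assay, a 2.5-fold lower number (0.40 log units; beyond the scatter) from compound 1 to compound 2 and a 1.2-fold higher number (0.09 log units; within the scatter) from compound 3 to compound 4, 3.1-fold (0.50 log units) apart, beyond the scatter of two such steps. This shows that the step seen on one core cannot simply be assumed on the other, but two steps give no reason for the difference and no rule for other cores in this series.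

The compounds shown leave open whether a chloro or a methyl group in the same place would also behave differently on the two cores. They also leave open how the change would behave on any third core.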